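Shortening the alkoxymethyl chain on the shared core

A few compounds are considered here, and "the series" means these few. Any claim that something is new, unique, unknown or untested is made for them only; others in the source may bear on it.

Measured compounds:
compound 1 `COc1ccc2c(c1)[n+]([O-])nc(NCOCc1ccccc1)[n+]2[O-]` — 8580 nM
compound 2 `CCCCCOCNc1n[n+]([O-])c2ccccc2[n+]1[O-]` — 9200 nM
compound 3 `CCCCCOCNc1n[n+]([O-])c2cc(OC)ccc2[n+]1[O-]` — 3630 nM

Read-out throughout is a functional assay on PC-3 cells (Homo sapiens) for cytotoxicity, read by MTT assay, with a stated time of 72 h; a higher number here means a weaker inhibitor, a lower number a stronger inhibitor. Compound 2 gives the highest number of the three; compound 1 sits within the scatter of it, so no order between those two can be claimed, while compound 3 lies beyond the scatter below compound 2, as shown by a 2.5-fold lower number from compound 2 to compound 3 (0.40 log units; beyond the scatter). The other measured step, a 2.4-fold lower number from compound 1 to compound 3 (0.37 log units; beyond the scatter), replaces phenyl by butyl at the chain end and is modest.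

Compound 4 `CCCOCNc1n[n+]([O-])c2ccccc2[n+]1[O-]` is not yet measured. It differs from compound 2 by hydrogen in place of ethyl on a saturated chain carbon, three bonds along the chain from an oxygen on a saturated carbon, which cut one bond further out reads pentyl to propyl. Within the data shown here, no measured pair changes the chain length alone, so neither step bears directly on it; the nearest, the swap of phenyl for butyl in compound 3 a 2.4-fold lower number from compound 1 to compound 3 (0.37 log units; beyond the scatter), is modest. Compound 4 is therefore expected to stay near compound 2, with a step of a 1.2-fold higher number from compound 2 to compound 4 (0.08 log units; within the scatter) not beyond the scatter. The estimate for compound 4 is 11000 nM, in the range 5000 nM to 25000 nM.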

Compound 4, half-maximal inhibitory concentration: 14200 nM
The estimate for compound 4 lay 1.3-fold (0.11 log units) below the measured number; low and high end bracket the measured number.
By their numbers in this assay, from the lowest: compound 3; then compounds 1, 2 and 4 (each within the scatter of the next).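

In this assay, among these compounds, the change of chain length alone on the shared core can now be read for the first time, and the step (a 1.5-fold higher number from compound 2 to compound 4 (0.19 log units; within the scatter)) stays within the scatter, so no order between these two compounds can be claimed. Cutting pentyl to propyl at this place on the saturated chain therefore gives no step that can be told from repeat scatter, whereas methoxy in place of hydrogen on an aromatic carbon (a 2.5-fold lower number from compound 2 to compound 3 (0.40 log units; beyond the scatter)) lies beyond it. No measured data are available to explain either reading.

On these data alone, whether a longer chain than pentyl, or a chain ending in an amine or a carboxylic acid, would give a step beyond the scatter remains open. Also open, as far as these compounds go, is whether methoxy on the aromatic carbon gives a comparable step with the propyl chain.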